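Swapping a methyl for a chloro on the aryl ring

A few compounds are considered here, and "the series" means these few. Any claim that something is new, unique, unknown or untested is made for them only; others in the source may bear on it.

Compound 1 `CCOC(=O)c1c(-c2cc3ccccc3oc2=O)nn(-c2cccc(Cl)c2)c1C(=O)OCC`: 22000 nM
Compound 2 `CCOC(=O)c1c(-c2cc3ccc(OC)cc3oc2=O)nn(-c2ccccc2)c1C(=O)OCC`: 140000 nM
Compound 3 `CCOC(=O)c1c(-c2cc3ccc(OC)cc3oc2=O)nn(-c2cccc(C)c2)c1C(=O)OCC`: 35000 nM

In a functional assay on HeLa cells (Homo sapiens) for cytotoxicity, read by MTT assay, with a stated time of 48 h (a lower number here means a stronger inhibitor, a higher number a weaker inhibitor), compound 3 gives the second highest of the three numbers. Its nearest neighbour is compound 1, whose value is within the scatter of it; compound 2 lies furthest away, and the step of a 4.0-fold lower number from compound 2 to compound 3 (0.60 log units; beyond the scatter), methyl in place of hydrogen on an aromatic carbon, is modest but beyond the scatter. Compound 4 `CCOC(=O)c1c(-c2cc3ccc(OC)cc3oc2=O)nn(-c2cccc(Cl)c2)c1C(=O)OCC` differs from compound 3 by chloro in place of methyl on an aromatic carbon, a change from 3-methylphenyl to 3-chlorophenyl. Among the measured compounds shown here, no measured step covers this exact swap. Compound 1, which already carries the chloro without the methoxy, sits close to compound 3, so the expected step of a 1.4-fold lower number from compound 3 to compound 4 (0.15 log units; within the scatter) is small. The estimate for compound 4 in this assay is 25000 nM, in the range 10000 nM to 60000 nM.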

Compound 4, half-maximal inhibitory concentration: 205000 nM
Beside the measured number, compound 4's estimate is 8.2-fold (0.91 log units) below it; the whole stated range lies below it.
By their numbers in this assay, from the lowest: compounds 1 and 3 (each within the scatter of the next); then compounds 2 and 4 (each within the scatter of the next).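

At the position meta to a large group, methyl and chloro are not interchangeable in this assay, with methoxy on the core: a 5.9-fold higher number from compound 3 to compound 4 (0.77 log units; beyond the scatter). With that methoxy present, chloro cannot be told apart from hydrogen: a 1.5-fold higher number from compound 2 to compound 4 (0.17 log units; within the scatter). With chloro held fixed, methoxy in place of hydrogen gives a 9.3-fold higher number from compound 1 to compound 4 (0.97 log units; beyond the scatter), so the result for chloro without methoxy does not carry over to the methoxy-bearing core.

Nothing here explains why these steps differ. As far as these compounds go, how an amine or a carboxylic acid at this position would behave also remains open.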